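The compounds below may be only part of what the source reports. "The series", "measured", "known", "first", "only" and "open" are said of these compounds alone.

Measured compounds in the series:

compound 1 `CCN(CC)CCCNc1nc(-c2ccc(NC(=O)Nc3ccccc3)cc2)nc2c(Cl)c(Cl)sc12` gives 850 nM in a functional assay on NCI-H460 cells (Homo sapiens) for cytotoxicity, read by MTT assay, with a stated time of 72 h; a lower number here means a stronger inhibitor, a higher number a weaker inhibitor
compound 2 `CCN(CC)CCCNc1nc(-c2ccc(NC(=O)Nc3ccccc3)cc2)nc2ccsc12` gives 680 nM in this assay
compound 3 `CCN(CC)CCCNc1nc(-c2ccc(NC(=O)Nc3ccc(F)cc3)cc2)nc2ccsc12` gives 290 nM in this assay

Compound 1 carries the highest number of the three. Its nearest neighbour is compound 2, and the two values lie within the scatter of each other, so no order between them is claimed. Against compound 3 the gap is beyond the scatter.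

The unmeasured compound 4 `CCN(CC)CCCNc1nc(-c2ccc(NC(=O)Nc3ccccc3Cl)cc2)nc2c(Cl)c(Cl)sc12` differs from compound 1 by chloro in place of hydrogen on an aromatic carbon; cut one bond further out this reads phenyl to 2-chlorophenyl, or phenylcarbamoyl to (2-chlorophenyl)carbamoyl, on the terminal phenyl of the urea.

Among the compounds with values here, only one measured step bears on this change, and loosely: a 2.3-fold lower number from compound 2 to compound 3 (0.37 log units; beyond the scatter), a halogen in place of hydrogen on the same terminal phenyl, though a different halogen at a different place on the ring and on a core without the two chloro groups. That step was modest and in the direction of a lower number. A smaller version of it is expected for compound 4, a step of a 1.4-fold lower number from compound 1 to compound 4 (0.15 log units; within the scatter), with a real chance of no change beyond the scatter.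

Compound 4 is therefore estimated at 600 nM, within a range of 250 nM to 1500 nM.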

Compound 4, half-maximal inhibitory concentration: 330 nM
For compound 4 the middle estimate is 1.8-fold (0.26 log units) above the measured one; the measured number falls inside the stated range.
By their numbers in this assay, from the lowest: compounds 3 and 4 (each within the scatter of the next); then compounds 2 and 1 (each within the scatter of the next).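

In this assay, the step of a 2.6-fold lower number from compound 1 to compound 4 (0.41 log units; beyond the scatter) shows that chloro on the terminal phenyl of the urea, ortho to a large group, lowers the number beyond the scatter on the core of compound 1, which carries the two chloro groups. The earlier step of a 2.3-fold lower number from compound 2 to compound 3 (0.37 log units; beyond the scatter) showed a lower number only for fluoro on the core without those two chloro groups, so the terminal phenyl now responds to a halogen in both settings, and neither step shown goes against this, though each is modest and they differ in halogen, ring place and core. No measurement on hand explains why phenyl to 2-chlorophenyl lowers the number.

Still open, from the compounds shown here alone, is whether this step depends on chloro itself, since fluoro, bromo, methyl, methoxy or an amine at the same ring place would separate a halogen-specific result from a more general one. Also open, going by these compounds, is whether 2-chlorophenyl gives a similar step on the core without the two chloro groups, and whether chloro elsewhere on the terminal phenyl matches it.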